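A few compounds are considered here, and "the series" means these few. Any claim that something is new, unique, unknown or untested is made for them only; others in the source may bear on it.

Measured compounds:
- compound 1 `Cn1c(=O)c(=O)n(C2CCCC2)c2nc(N/N=C/c3ccccc3)ncc21`: 48200 nM in a functional assay on PC-3 cells (Homo sapiens) for antiproliferative activity, read by MTT assay; a higher number here means a weaker inhibitor, a lower number a stronger inhibitor
- compound 2 `Cn1c(=O)c(=O)n(C2CCCC2)c2nc(N/N=C/c3ccc(O)cc3)ncc21`: in this assay only a limit, > 100000 nM

Within the data shown here, compound 1 is the only member with a number. Compound 2 gives in this assay no number at all but a limit, > 100000 nM; it sits at the limit of > 100000 nM in this assay, at which 1 of the 2 values shown sits, so its standing is known only as a range that begins there. Among the measured compounds shown here, the single measured step, an at least 2.0-fold higher number from compound 1 to compound 2 (0.31 log units; beyond the scatter), is accordingly a bound rather than an exact size, but it lies beyond the scatter and shows that the hydroxy in place of hydrogen on an aromatic carbon weakened the inhibitor.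

Compound 3 `COc1cccc(/C=N/Nc2ncc3c(n2)n(C2CCCC2)c(=O)c(=O)n3C)c1` differs from compound 2 by 3-methoxyphenyl in place of 4-hydroxyphenyl on a carbon with a double bond to nitrogen. The hydroxy that carried the weakening is gone; the methoxy enters at a different position of the ring. For the measured compounds named here, the only step that bears on this is an at least 2.0-fold higher number from compound 1 to compound 2 (0.31 log units; beyond the scatter), which suggests that removing the hydroxy should undo part of that loss. Compound 3 is therefore expected to move back toward compound 1, by an at least 1.6-fold lower number from compound 2 to compound 3 (0.22 log units; that floor lies within the scatter), a lower number, though the limit on compound 2 leaves its size uncertain. Compound 3 is estimated at 60000 nM, with a range from 25000 nM to 150000 nM.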

Compound 3, half-maximal inhibitory concentration: 20700 nM
The estimate for compound 3 lay 2.9-fold (0.46 log units) above the measured number, outside the stated range (below it).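

In this assay, a methoxy group added to the unsubstituted phenyl group gives a 2.3-fold lower number from compound 1 to compound 3 (0.37 log units; beyond the scatter), so a substituent on this phenyl group can strengthen the inhibitor as well as weaken it, and the unsubstituted compound 1 does not mark the best value this position can give. Exchanging 4-hydroxyphenyl for 3-methoxyphenyl on the carbon with a double bond to nitrogen gives an at least 4.8-fold lower number from compound 2 to compound 3 (0.68 log units; beyond the scatter), which shows that the two substituted compounds are clearly separated and that the substituent's identity, its place on the phenyl group, or both matter in this assay. Compound 2 has only a limit of the assay, > 100000 nM, and not a number, so this step is a bound whose full size stays unknown: the limit of > 100000 nM in this assay, at which 1 of the 3 values shown sits.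

The exchange alters the group and its place together, so the compounds shown cannot separate the two, and 4-methoxyphenyl and 3-hydroxyphenyl are the groups that would. On these data alone, it also remains open whether the gain extends to a longer chain such as ethoxy, or to an amine or a carboxylic acid on the phenyl group.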